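The source may hold more compounds than are shown below. What is called first, only, known or untested is meant among the compounds shown, and "the series" means these compounds.

Compound 1 `CC(C)[C@H](NC(=O)COc1cccc2ccccc12)C(=O)N[C@@H](CC(=O)O)C(=O)CSc1nnc(-c2ccccc2)o1`: 150000 nM
Compound 2 `CC(C)[C@H](NC(=O)COc1cccc2ccccc12)C(=O)N[C@@H](CC(=O)O)C(=O)COn1nnc2ccccc21`: > 200000 nM

Compounds 1 and 2 share one core and differ only in the group on the saturated chain carbon bound to a carbonyl carbon. In a functional assay on Jurkat cells (Homo sapiens) for inhibition (on this read-out lower numbers stand for stronger inhibition and higher numbers for weaker inhibition), compound 1 gives 150000 nM. In this assay compound 2 gives > 200000 nM, which is a limit of the assay and not a number. The step of an at least 1.3-fold higher number from compound 1 to compound 2 (0.12 log units; that floor lies within the scatter) therefore has only a floor, and compound 2 stands at the limit of > 200000 nM in this assay, at which 1 of the 2 values shown sits.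

Compound 3 `CC(C)[C@H](NC(=O)COc1cccc2ccccc12)C(=O)N[C@@H](CC(=O)O)C(=O)COc1nncc(Cl)c1Cl` keeps the core of compound 2 and changes the group on the oxygen: a group of 8 heavy atoms (4 carbon, 2 nitrogen, 2 chlorine; one six-membered aromatic ring with 2 hetero atoms) in place of a group of 9 heavy atoms (6 carbon, 3 nitrogen; one five-membered aromatic ring with 3 hetero atoms, one six-membered aromatic ring of carbon only), on an oxygen on a saturated carbon. Going by the values given here, no measured step concerns the 4,5-dichloropyridazin-3-yl group, and the single measured step, an at least 1.3-fold higher number from compound 1 to compound 2 (0.12 log units; that floor lies within the scatter), covers a different exchange, so it offers little guidance for this one. The expectation is therefore a number in the same region as compound 2, with an expected step of an at least 1.3-fold lower number from compound 2 to compound 3 (0.12 log units; that floor lies within the scatter) that may well lie within the scatter. Compound 3 is estimated at 150000 nM, with an expected range from 40000 nM to 300000 nM, and a real chance that only a limit is reported.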

Compound 3, half-maximal inhibitory concentration: > 200000 nM
Compound 3: only a limit was reported (the forecaster's own chance of this, stated with the estimate: 50%); at least 1.3-fold (0.12 log units) between middle value and limit.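

Compound 3, like compound 2, returns only a limit of the assay and not a number, so the step from compound 2 to compound 3 cannot be read, and this exchange on the oxygen has no measurable size. A second, quite different ring on that oxygen has now ended at the same limit: the limit of > 200000 nM in this assay, at which 2 of the 3 values shown sit.

Going by these compounds alone, the one step that can be read is an at least 1.3-fold higher number from compound 1 to compound 3 (0.12 log units; that floor lies within the scatter), so (4,5-dichloropyridazin-3-yl)oxy cannot be told apart from (5-phenyl-1,3,4-oxadiazol-2-yl)sulfanyl on the saturated chain carbon bound to a carbonyl carbon. Compound 1 remains the only one of the three that gives an actual number, 150000 nM.

On these data alone, it stays open whether the two compounds at the limit truly differ, since a limit hides how far past it each one lies. As far as these compounds go, it also stays open whether a plain phenyl ring on the oxygen, or an amine in place of that oxygen, would bring the number in this assay clearly down from the region these compounds occupy.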